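A few compounds are considered here, and "the series" means these few. Any claim that something is new, unique, unknown or untested is made for them only; others in the source may bear on it.

Measured compounds in a functional assay on MCF7 cells (Homo sapiens) for inhibition, read by sulforhodamine B assay, with a stated time of 72 h; a lower number here means a stronger inhibitor of growth, a higher number a weaker inhibitor of growth:
compound 1 `NC(=O)/C=C/c1ccncc1-c1ccc2ccccc2c1` gives > 10000 nM, which is a limit of the assay.
compound 2 `COC1CN(C(=O)/C=C/c2ccncc2-c2ccc3ccccc3c2)C1` gives > 10000 nM, which is a limit of the assay.
compound 3 `O=C(O)CCc1ccncc1-c1ccc2ccccc2c1` gives > 10000 nM, which is a limit of the assay.

Compound 3 stands only as a limit in this assay, and the two other values shown are limits as well; all three sit at the limit of > 10000 nM in this assay, at which 3 of the 3 values shown sit. The step that the two limits leave unreadable from compound 1 to compound 2 is left unreadable by its two limits, as is the step that the two limits leave unreadable from compound 1 to compound 3, so neither gives a readable size in this assay.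

Compound 4 `COC(=O)/C=C/c1ccncc1-c1ccc2ccccc2c1` differs from compound 3 by 2-(methoxycarbonyl)ethenyl in place of 2-carboxyethyl on an aromatic carbon. The step that touches the same position, from compound 1 to compound 3, is unreadable, and no measured step reports a number in this assay, so no direction or size can be read from the series; with every shown value at the limit, compound 4 is expected to remain at or near that limit too. The expected step is a step that the limit leaves unreadable from compound 3 to compound 4. The estimate for compound 4 in this assay is 15000 nM, within 4000 nM to 60000 nM.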

Compound 4, concentration for 50% growth inhibition: 8170 nM
For compound 4 the middle estimate is 1.8-fold (0.26 log units) above the measured one; the measured number falls inside the stated range.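

In this assay compound 4 gives 8170 nM, the only number among the compounds shown rather than a limit. With 2-(methoxycarbonyl)ethenyl in place of 2-carboxyethyl on this aromatic carbon the result is an at least 1.2-fold lower number from compound 3 to compound 4 (0.08 log units; that floor lies within the scatter), while on the carbonyl carbon methoxy gives an at least 1.2-fold lower number from compound 2 to compound 4 (0.08 log units; that floor lies within the scatter) in place of 3-methoxyazetidin-1-yl and an at least 1.2-fold lower number from compound 1 to compound 4 (0.08 log units; that floor lies within the scatter) in place of amino. Each floor lies within the scatter, so no step is shown to exceed it and the full sizes stay unread: the limit of > 10000 nM in this assay, at which 3 of the 4 values shown sit.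

The change from compound 3 to compound 4 alters the double bond and the chain end together, and the compounds shown do not separate the two. Going by these compounds, whether a 2-carboxyethenyl group, a saturated 2-(methoxycarbonyl)ethyl chain or a longer ester such as an ethyl ester would shift the number at this aromatic carbon also remains open.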